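Trimming the nitrogen substituent of compound 2 down to methyl

The compounds below may be only part of what the source reports. "The series", "measured", "known", "first", "only" and "open" are said of these compounds alone.

Going by the values given here, compound 2 `CC(C)(CO)/N=c1\c(O)c(O)\c1=N/Cc1ccc(C#N)cc1` stands at the highest of the three numbers so far in a functional assay for inhibition, with Rattus norvegicus as the target; a higher number here means a weaker inhibitor, a lower number a stronger inhibitor: compound 2 gives 21300 nM. Its nearest neighbour, compound 1 `CC[C@H](C)/N=c1\c(O)c(O)\c1=N/Cc1ccc(C#N)cc1`, gives 2200 nM in this assay. Compound 3 `CCC(C)(C)/N=c1\c(O)c(O)\c1=N/Cc1c(C)cc(C)cc1C` differs from compound 1 at two places and is the furthest from compound 2; in this assay compound 3 gives 310 nM.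

Compound 4 `C/N=c1\c(O)c(O)\c1=N/Cc1ccc(C#N)cc1` is the unmeasured member. (methyl in place of 1-(hydroxymethyl)-1-methylethyl on a double-bonded nitrogen). Among the compounds with values here, one measured step bears on this place: a 9.7-fold higher number from compound 1 to compound 2 (0.99 log units; beyond the scatter), in which the group that enters is exactly the group that now leaves. That step ran toward a weaker inhibitor and lay beyond the scatter, so removing the 1-(hydroxymethyl)-1-methylethyl again is expected to run the other way. Methyl is not sec-butyl, however, so a full return to the number of compound 1 is not assured, and no measured pair shows methyl on the double-bonded nitrogen in this series.

The expected step is therefore a 2.7-fold lower number from compound 2 to compound 4 (0.43 log units; beyond the scatter), toward a stronger inhibitor and beyond the scatter. The estimate for compound 4 in this assay is 8000 nM, with a range from 1500 nM to 40000 nM.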

Compound 4, half-maximal inhibitory concentration: > 30000 nM
Compound 4: a limit, no number (the forecaster's own chance of this, stated with the estimate: 5%); middle value at least 3.7-fold (0.57 log units) away from the limit.
By their numbers in this assay, from the lowest: compound 3; then compound 1; then compound 2. At a limit, above all of these: compound 4.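

Methyl on the double-bonded nitrogen does not restore the activity seen with sec-butyl: in this assay compound 4 gives > 30000 nM as a limit of the assay and not a number, the only such reading in this set: the limit of > 30000 nM in this assay, at which 1 of the 4 values shown sits.

Against sec-butyl the change is clear, with an at least 13-fold higher number from compound 1 to compound 4 (1.13 log units; beyond the scatter) as the step, so both departures from sec-butyl shown here, to methyl and to 1-(hydroxymethyl)-1-methylethyl, run toward a weaker inhibitor. Against compound 2 the step is an at least 1.4-fold higher number from compound 2 to compound 4 (0.14 log units; that floor lies within the scatter) and its floor lies within the scatter, so removing the 1-(hydroxymethyl)-1-methylethyl gives no measurable recovery and compound 4 and compound 2 cannot be placed in order.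

Open, as far as these compounds go, is where ethyl, isopropyl or tert-butyl on the double-bonded nitrogen would fall, with the core of compound 1 otherwise unchanged, and so whether the gap between methyl and sec-butyl follows chain length or branching. Also open, from the compounds shown here alone, is whether the hydroxyl of compound 2 or its branched carbon frame goes with the step away from compound 1, which tert-butyl and a primary amine in place of that hydroxyl would help to separate.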